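Swapping a Methyl for Hydroxybenzyl on an Amine

The compounds below may be only part of what the source reports. "The series", "measured", "known", "first", "only" and "open" are said of these compounds alone.

Three compounds share one core and differ only in the amino group on an aromatic carbon. Compound 1 `CCCCNc1cc(C)nc2c(-c3ccc(Cl)cc3Cl)nn(C)c12` gives 170 nM in an assay on HEK293 cells for displacement of a labelled ligand from corticotropin-releasing factor receptor 1 (Homo sapiens); a higher number here means a weaker inhibitor, a lower number a stronger inhibitor. Compound 2 `CCCN(C)c1cc(C)nc2c(-c3ccc(Cl)cc3Cl)nn(C)c12` gives 24 nM in this assay, the second highest of the three numbers, between compound 1 and compound 3. Compound 3 `CCCCN(CCCC)c1cc(C)nc2c(-c3ccc(Cl)cc3Cl)nn(C)c12` gives 0.62 nM in this assay. The steps were a 7.1-fold lower number from compound 1 to compound 2 (0.85 log units; beyond the scatter), a 270-fold lower number from compound 1 to compound 3 (2.44 log units; beyond the scatter) and a 39-fold lower number from compound 2 to compound 3 (1.59 log units; beyond the scatter): each time the amino substituents grew, the number fell. Compound 4 `CCCN(Cc1ccc(O)cc1)c1cc(C)nc2c(-c3ccc(Cl)cc3Cl)nn(C)c12` differs from compound 2 by 4-hydroxyphenyl in place of hydrogen on a saturated chain carbon bound to a nitrogen on an aromatic ring. Among the compounds with values here, the steps that bear on it, a 270-fold lower number from compound 1 to compound 3 (2.44 log units; beyond the scatter) and a 39-fold lower number from compound 2 to compound 3 (1.59 log units; beyond the scatter), both enlarged the substituents on the same nitrogen and both were large. Here the entering group is a 4-hydroxyphenyl ring rather than a plain chain, so a lower number is expected, though a smaller step than a 39-fold lower number from compound 2 to compound 3 (1.59 log units; beyond the scatter). For compound 4 the expected step is a 4.8-fold lower number from compound 2 to compound 4 (0.68 log units; beyond the scatter). Compound 4 is estimated at 5 nM in this assay, with a range from 1 nM to 30 nM.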

Compound 4, inhibition constant: 13 nM
For compound 4 the middle estimate is 2.6-fold (0.41 log units) below the measured one; the measured number falls inside the stated range.
By their numbers in this assay, from the lowest: compound 3; then compounds 4 and 2 (each within the scatter of the next); then compound 1.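

Putting 4-hydroxybenzyl in place of the methyl on this nitrogen of compound 2 brings in a six-membered aromatic ring carrying a hydroxyl, yet this assay gives only a 1.8-fold lower number from compound 2 to compound 4 (0.27 log units; within the scatter) and so does not separate the two compounds. The earlier enlargement on the same nitrogen, a 39-fold lower number from compound 2 to compound 3 (1.59 log units; beyond the scatter), lay well beyond the scatter, which shows that a bigger group here does not always bring a clear step and that the ring is accepted without a clear loss. Nothing measured here explains why these two changes differ.

The compounds shown leave open whether the hydroxyl matters at all. A plain benzyl, a 4-methoxybenzyl or a 4-aminobenzyl on this nitrogen would show what the ring does alone and what its substituent adds.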